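This account rests on a few compounds, and the source may have more. Where it says the series, first, only, none or still open, it means among the compounds named here.

In a functional assay on HeLa cells (Homo sapiens) for antiproliferative activity, read by sulforhodamine B assay, with a stated time of 48 h (on this read-out lower numbers stand for stronger inhibition and higher numbers for weaker inhibition), compound 1, `COc1cc(OC)c2sc(-c3ccc(N/C=C\C(=O)c4ccc(OC)c([N+](=O)[O-])c4)cc3)nc2c1`, gives 12900 nM.
In this assay compound 2, `COc1ccc2nc(-c3ccc(N/C=C\C(=O)c4ccc(OC)c([N+](=O)[O-])c4)cc3)sc2c1`, gives 17600 nM.
In this assay compound 3, `COc1ccc(C(=O)/C=C\Nc2ccc(-c3nc4cc(OC)c(OC)c(OC)c4s3)cc2)cc1[N+](=O)[O-]`, gives 11400 nM.

Compound 3 arises from compound 1 by methoxy in place of hydrogen on an aromatic carbon, and this gave a 1.1-fold lower number from compound 1 to compound 3 (0.05 log units; within the scatter). The difference between the core of compound 1 and the core of compound 2 is not broken down here. Compound 4, `COc1ccc2nc(-c3ccc(N/C=C\C(=O)c4cc(OC)c(OC)c([N+](=O)[O-])c4)cc3)sc2c1`, is not yet measured; it arises from compound 2 by methoxy in place of hydrogen on an aromatic carbon. This is the same kind of change as that from compound 1 to compound 3, but the surroundings differ: in compound 3 the new group sits on a ring that is part of a fused system, ortho to two methoxy groups, whereas in compound 4 it sits ortho to one methoxy group, meta to a large group and meta to a nitro group. Because the earlier step was a 1.1-fold lower number from compound 1 to compound 3 (0.05 log units; within the scatter), a similarly small step is expected, a 1.1-fold lower number from compound 2 to compound 4 (0.04 log units; within the scatter). In this assay compound 4 is therefore estimated at 16000 nM, plausibly between 8000 nM and 32000 nM.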

Compound 4, half-maximal inhibitory concentration: 16100 nM
Compound 4: the middle estimate sits 1.0-fold (0.00 log units) below what was measured; the measured number falls inside the stated range.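

In this assay, putting a methoxy group in place of hydrogen on an aromatic carbon gives a 1.1-fold lower number from compound 2 to compound 4 (0.04 log units; within the scatter), and the two cores tested so far agree: the same change on two cores in this assay, a 1.1-fold lower number (0.05 log units; within the scatter) from compound 1 to compound 3 and a 1.1-fold lower number (0.04 log units; within the scatter) from compound 2 to compound 4, 1.0-fold (0.01 log units) apart, within the scatter of two such steps. For the compounds shown here, each step is itself within the scatter, so this agreement shows only that the change leaves no measurable mark on the number in either of these two pairs. It does not show that the change would stay as small on another core or at another place on the ring, and two pairs are too few for a rule.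

From the compounds shown here alone, whether an amine, a carboxylic acid or a longer chain on this same carbon would shift the number remains open. All four compounds also carry the nitro group, so the effect of replacing it with, for example, a nitrile is open too.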